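Methoxy on the distal phenyl of the oxadiazole series

This account rests on a few compounds, and the source may have more. Where it says the series, first, only, none or still open, it means among the compounds named here.

Measured in an assay on HL-60 cells for inhibition of glutathione S-transferase P (Homo sapiens); on this read-out higher numbers stand for weaker inhibition and lower numbers for stronger inhibition:
- compound 1 `C=C(C)C(=O)c1ccc(OCc2nc(-c3ccc(C(F)(F)F)cc3)no2)cc1Cl`: 700 nM
- compound 2 `C=C(CC)C(=O)c1ccc(OCc2nc(-c3ccccc3)no2)c(Cl)c1Cl`: 3600 nM

Compound 2 holds the highest of the two numbers recorded in this assay. Its nearest neighbour is compound 1, which gives a lower number, and the gap between the two lies beyond the usual scatter. Among the measured compounds shown here, the two compounds differ in more than one place, so no single step can be read from them; their values show only that compound 1 is the stronger inhibitor of the pair.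

The next compound, compound 3 `C=C(CC)C(=O)c1ccc(OCc2nc(-c3ccc(OC)cc3)no2)c(Cl)c1Cl`, departs from compound 2 in one place: methoxy in place of hydrogen on an aromatic carbon. Cut one bond further out, the change reads phenyl to 4-methoxyphenyl. For the measured compounds named here, no measured pair shows this exact change, so nothing in the data fixes the size of the step. A modest shift is expected, written as a 1.4-fold lower number from compound 2 to compound 3 (0.16 log units; within the scatter), with the direction left open within the scatter. On that basis compound 3 is estimated at 2500 nM, with a range from 800 nM to 8000 nM.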

Compound 3, half-maximal inhibitory concentration: 3800 nM
The estimate for compound 3 lay 1.5-fold (0.18 log units) below the measured number; measured number inside the range.
By their numbers in this assay, from the lowest: compound 1; then compounds 2 and 3 (each within the scatter of the next).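

In this assay the series now has its first step in one place, a 1.1-fold higher number from compound 2 to compound 3 (0.02 log units; within the scatter), for methoxy in place of hydrogen on an aromatic carbon of a six-membered aromatic ring of carbon only, para to a large group. With the rest of the structure shared, phenyl and 4-methoxyphenyl cannot be told apart on this read-out, so adding a methoxy with its 2 heavy atoms and 1 hydrogen-bond acceptor at this place gives no measurable separation between compound 2 and compound 3. No measurement at hand explains this result.

As far as these compounds go, it remains open whether this place would also give no separation with a different group, such as an amine, a carboxylic acid or a longer alkoxy chain, since a single substituent on a single background cannot define what the position tolerates. The lower number of compound 1 at 700 nM also stays unassigned, as it differs from both compound 2 and compound 3 in more than one place, and the steps to it cannot be read.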